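Swapping a Saturated Ring for a Fluorinated Phenyl

The compounds below may be only part of what the source reports. "The series", "measured", "known", "first", "only" and "open" are said of these compounds alone.

This set follows three compounds that share one core and differ only in the group attached to it. Compound 1 `C[C@]1(CN2CCc3nc(-c4ccc(F)cc4)oc3C2)Cn2cc([N+](=O)[O-])nc2O1` was tested in an ADME assay on Vero cells (Chlorocebus sabaeus) for cytotoxicity, read by MTT assay, with a stated time of 72 h; on this read-out lower numbers stand for higher toxicity in this test and higher numbers for lower toxicity in this test. In this assay compound 1 gives > 32 ug/mL, which is a limit of the assay rather than a number. Compound 2 `C[C@]1(CN2CCc3nc(C4CCOCC4)ccc3C2)Cn2cc([N+](=O)[O-])nc2O1` carries no result in this assay: its entry reads "not determined" (no result reported). Compound 2 therefore stands without a number of its own. For the measured compounds named here, the one value on show is the limit of > 32 ug/mL in this assay, at which 1 of the 2 values shown sits, reached by compound 1. Compound 3 `C[C@]1(CN2CCc3nc(-c4cc(F)c(F)c(F)c4)ccc3C2)Cn2cc([N+](=O)[O-])nc2O1` is the compound still to be measured. It differs from compound 2 as follows: 3,4,5-trifluorophenyl in place of oxan-4-yl on an aromatic carbon. Going by the values given here, with no measured step between any two compounds, the step from compound 2 to compound 3 in this assay is expected to stay within the scatter, in no set direction. Compound 3 is expected to give about 40 ug/mL in this assay, within a range from 16 ug/mL to 100 ug/mL.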

Compound 3, half-maximal cytotoxic concentration: > 32 ug/mL
Compound 3 gave a limit, no number; the forecaster's own chance of this, stated with the estimate: 75%; the middle value is on the limit's open side.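

In this assay, for the compounds shown here, compound 3 gives > 32 ug/mL, which is a limit of the assay and not a number, so no step from compound 2 to compound 3 can be read. The compounds shown leave open what exchanging oxan-4-yl for 3,4,5-trifluorophenyl does to this read-out.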